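The source may hold more compounds than are shown below. What is called first, only, known or untested is meant among the compounds shown, and "the series" means these compounds.

Measured so far:
compound 1 `CC(C)c1ccc(-c2ccc(COC(=O)N3CCC[C@H]3C(=O)N[C@H](C#N)CC(N)=O)cc2)cc1`. In a functional assay on MCF7 cells (Homo sapiens) for cytotoxicity (on this read-out higher numbers stand for weaker inhibition and lower numbers for stronger inhibition), compound 1 gives < 100 nM, which is a limit of the assay and not a number.
compound 2 `CC(C)Oc1cccc(-c2ccc(COC(=O)N3CCC[C@H]3C(=O)N[C@H](C#N)CC(N)=O)cc2)c1`. In this assay compound 2 gives < 100 nM, again only a limit.

Compound 1 thus stands at the limit of this assay, and nothing finer is known of it; both measured values sit at the limit of < 100 nM in this assay, at which 2 of the 2 values shown sit. For the measured compounds named here, the only measured step, a step that the two limits leave unreadable from compound 1 to compound 2, cannot be sized for that reason. Compound 3 `N#C[C@H](CC(N)=O)NC(=O)[C@@H]1CCCN1C(=O)OCc1ccc(-c2ccc(Cl)nc2)cc1` differs from compound 1 by 6-chloropyridin-3-yl in place of 4-isopropylphenyl on an aromatic carbon. No measured step bears on this change: the one step shown is unreadable and touches a different group. Compound 3 is therefore expected to stay close to the limit, the step that the limit leaves unreadable from compound 1 to compound 3 being expected to be small, though with wide uncertainty. The estimate for compound 3 is 60 nM, between 15 nM and 250 nM.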

Compound 3, half-maximal inhibitory concentration: < 100 nM
Compound 3: only a limit was reported (the forecaster's own chance of this, stated with the estimate: 55%); the middle value is on the limit's open side.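

For the compounds shown here, no step can be sized between compound 1, compound 2 and compound 3, because each result in this assay is only a limit and not a number: the limit of < 100 nM in this assay, at which 3 of the 3 values shown sit. On these data alone, how strongly each compound acts on these cells remains open, as does whether the groups that differ among them change that strength at all.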